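Moving the methyl: 4-methylphenyl to 3-methylphenyl

The source may report more compounds than this note shows. Statements on the series, on what has been measured and on what is new or still open speak of the compounds shown alone.

In a functional assay on HT-29 cells (Homo sapiens) for antiproliferative activity, read by MTT assay, with a stated time of 72 h (on this read-out lower numbers stand for stronger inhibition and higher numbers for weaker inhibition), compound 1 `CCCn1ccnc1-c1cc(OC)c(OC)c(OC)c1` gives > 100000 nM, which is a limit. Compound 2 `CCCCn1ccnc1-c1cc(OC)c(OC)c(OC)c1` gives > 100000 nM, also a limit. Going by the values given here, compound 3 `COc1cc(-c2nccn2-c2ccc(C)cc2)cc(OC)c1OC` gives 1600 nM, the only true number so far.

Compound 4 `COc1cc(-c2nccn2-c2cccc(C)c2)cc(OC)c1OC` differs from compound 3 as follows: 3-methylphenyl in place of 4-methylphenyl on an aromatic nitrogen. The group stays on the aromatic nitrogen, as 3-methylphenyl in place of 4-methylphenyl.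

The nearest evidence is an at least 62-fold lower number from compound 1 to compound 3 (1.79 log units; beyond the scatter) and an at least 62-fold lower number from compound 2 to compound 3 (1.79 log units; beyond the scatter), both large, while a step that the two limits leave unreadable from compound 1 to compound 2 adds nothing. Neither large step moves the methyl, so they bear only indirectly.

In this assay the expected result is a 1.6-fold higher number from compound 3 to compound 4 (0.19 log units; within the scatter), with no shift beyond the scatter anticipated. For compound 4 the estimate is 2500 nM, with an expected range of 500 nM to 12000 nM.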

Compound 4, half-maximal inhibitory concentration: 14600 nM
Compound 4: middle estimate off by 5.8-fold (0.77 log units), on the low side; measured number above the stated range.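

Within this assay moving the methyl alone gives a 9.1-fold higher number from compound 3 to compound 4 (0.96 log units; beyond the scatter) as its step, so the place of the methyl on this phenyl group counts, not merely the presence of an aryl group. Against the alkyl chains, the steps of an at least 6.8-fold lower number from compound 2 to compound 4 (0.83 log units; beyond the scatter) and an at least 6.8-fold lower number from compound 1 to compound 4 (0.83 log units; beyond the scatter) still favour the 3-methylphenyl group. Both start from a limit, not a number: the limit of > 100000 nM in this assay, at which 2 of the 4 values shown sit.

Open, as far as these compounds go, is whether 2-methylphenyl continues this order, and whether a methoxy group or a chlorine in place of the methyl keeps the same preference between the two positions.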